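Leaving morpholin-4-yl on the sulfonyl sulfur of compound 3

The compounds below may be only part of what the source reports. "The series", "measured", "known", "first", "only" and "open" are said of these compounds alone.

In a functional assay on A2780 cells (Homo sapiens) for cytotoxicity, read by sulforhodamine B assay, with a stated time of 72 h (a higher number here means a weaker inhibitor, a lower number a stronger inhibitor), compound 1 `O=C(NCc1ccc(S(=O)(=O)c2cc(F)cc(F)c2)cc1)N1Cc2ccncc2C1` gives 6.3 nM and compound 2 `O=C(NCc1ccc(S(=O)(=O)C2CCC(F)(F)CC2)cc1)N1Cc2ccncc2C1` gives 13 nM while compound 3 `O=C(NCc1ccc(S(=O)(=O)N2CCOCC2)cc1)N1Cc2ccncc2C1` gives 68 nM as the highest number of the three. Among the measured compounds shown here, the change to compound 4 `O=C(NCc1ccc(S(=O)(=O)N2CC3(CCOCC3)C2)cc1)N1Cc2ccncc2C1` is a group of 9 heavy atoms (7 carbon, 1 nitrogen, 1 oxygen; one four-membered non-aromatic ring with 1 hetero atom, one six-membered non-aromatic ring with 1 hetero atom) in place of a group of 6 heavy atoms (4 carbon, 1 nitrogen, 1 oxygen; one six-membered non-aromatic ring with 2 hetero atoms), on a sulfonyl sulfur and no measured compound carries the entering group. For the measured compounds named here, two measured steps bear on it: an 11-fold higher number from compound 1 to compound 3 (1.03 log units; beyond the scatter) is large and a 5.2-fold higher number from compound 2 to compound 3 (0.72 log units; beyond the scatter) is modest. Both end at morpholin-4-yl, so a modest step to a lower number is expected in this assay with wide uncertainty. The expected step is a 2.7-fold lower number from compound 3 to compound 4 (0.43 log units; beyond the scatter) on this estimate. The estimate for compound 4 is 25 nM with 8 nM to 80 nM as its expected range.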

Compound 4, half-maximal inhibitory concentration: 10 nM
Compound 4: the middle estimate sits 2.5-fold (0.40 log units) above what was measured; low and high end bracket the measured number.
By their numbers in this assay, from the lowest: compounds 1, 4 and 2 (each within the scatter of the next, the first and the last beyond it); then compound 3.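

In this assay, attachment through nitrogen on the sulfonyl sulfur is not tied to the highest number: both morpholin-4-yl and the entering group join that way, yet the change gives a 6.8-fold lower number from compound 3 to compound 4 (0.83 log units; beyond the scatter). The other steps, a 1.3-fold lower number from compound 2 to compound 4 (0.11 log units; within the scatter) and a 1.6-fold higher number from compound 1 to compound 4 (0.20 log units; within the scatter), place the entering group level with both the 4,4-difluorocyclohexyl and 3,5-difluorophenyl groups. Nothing available accounts for the change at this position.

Still open, from the compounds shown here alone, is whether azetidin-1-yl alone, without the six-membered ring, keeps this level. Also open, going by these compounds, is whether an all-carbon six-membered ring in place of the oxygen-containing one does so.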